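The source may report more compounds than this note shows. Statements on the series, on what has been measured and on what is new or still open speak of the compounds shown alone.

Working notes on the series. Compound 1 `O=C(O)c1ccc(S(=O)(=O)N2CCC(NS(=O)(=O)c3cc(S(=O)(=O)c4ccccc4)ccc3C(F)(F)F)CC2)cc1` gives 110 nM in an assay on U2OS cells for inhibition of secreted frizzled-related protein 1 (Homo sapiens), read by a luciferase reporter, with a stated time of 18 h (on this read-out higher numbers stand for an effect only at larger amounts of compound and lower numbers for an effect already at smaller amounts), the lowest number among the three measured compounds. Compound 2 `O=S(=O)(NC1CCN(S(=O)(=O)c2cccc(-c3nnn[nH]3)c2)CC1)c1cc(S(=O)(=O)c2ccccc2)ccc1C(F)(F)F` gives 1200 nM and compound 3 `CC(C)(C)OC(=O)N1CCC(C(=O)N2CCC(NS(=O)(=O)c3cc(S(=O)(=O)c4ccccc4)ccc3C(F)(F)F)CC2)CC1` gives 420 nM. Among the compounds with values here, the single measured step, an 11-fold higher number from compound 1 to compound 2 (1.04 log units; beyond the scatter), shows that replacing the group on the sulfonyl sulfur moves the read-out well beyond the scatter. Compound 4 `O=C([C@H]1CCNC1)N1CCC(NS(=O)(=O)c2cc(S(=O)(=O)c3ccccc3)ccc2C(F)(F)F)CC1` remains unmeasured; it differs from compound 1 by (pyrrolidin-3-yl)carbonyl in place of (4-carboxyphenyl)sulfonyl on an amine nitrogen in a ring. Within the data shown here, no measured step covers this exact change. The closest reference is compound 3, which likewise lacks the (4-carboxyphenyl)sulfonyl group and carries a carbonyl on that amine nitrogen, and its number stands above that of compound 1. A step upward is therefore expected for compound 4, of size a 5.5-fold higher number from compound 1 to compound 4 (0.74 log units; beyond the scatter), with the (pyrrolidin-3-yl)carbonyl group judged by analogy to compound 3 rather than from a direct comparison. Compound 4 is estimated at 600 nM, with a range of 150 nM to 3000 nM.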

Compound 4, half-maximal effective concentration: 700 nM
Compound 4: middle estimate off by 1.2-fold (0.07 log units), on the low side; measured number inside the range.
By their numbers in this assay, from the lowest: compound 1; then compounds 3, 4 and 2 (each within the scatter of the next, the first and the last beyond it).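

At the amine nitrogen in a ring, swapping the (4-carboxyphenyl)sulfonyl group for (pyrrolidin-3-yl)carbonyl gives a 6.4-fold higher number from compound 1 to compound 4 (0.80 log units; beyond the scatter), the first direct measure at this position: the effect persists without that aromatic ring or sulfonyl group, but at a cost beyond the scatter. Two different carbonyl-linked groups now lie within the scatter of each other in this assay, with compound 3 at 420 nM and compound 4 at 700 nM. No available measurement accounts for the step.

On these data alone, the change replaces the linking sulfonyl and the carboxyphenyl group together, so their separate contributions remain open. A 4-carboxybenzoyl group on the same nitrogen would separate them, while an acyclic aminoacetyl group would test whether the pyrrolidine ring matters.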